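Semicarbazone to oxime: one change on compound 1's core

A few compounds are considered here, and "the series" means these few. Any claim that something is new, unique, unknown or untested is made for them only; others in the source may bear on it.

Measured compounds:
- compound 1, `COc1cc2c(cc1CC=C(C)C)/C(=N/NC(N)=O)C[C@@H](c1ccc(O)cc1)O2`: 87%
- compound 2, `COc1cc2c(cc1CC=C(C)C)C(=O)C[C@@H](c1ccc(Oc3cccc([N+](=O)[O-])c3)cc1)O2`: 46%
- compound 3, `COc1ccc([C@@H]2C/C(=N/OCc3cn(-c4ccc(C#N)cc4)nn3)c3cc(CC=C(C)C)c(OC)cc3O2)cc1`: 50%

All three were tested in a functional assay on HCT-116 cells (Homo sapiens) for inhibition, read by sulforhodamine B assay, with a stated time of 48 h, tested at 50 uM; a lower number here means less inhibition of growth, a higher number more inhibition of growth at the concentration tested. Compound 1 stands highest of the three numbers. Compound 3 is the nearest to it, with a number that falls beyond the scatter below it, and compound 2 is the furthest, also beyond the scatter. No pair among these three differs in one place only, so none of the gaps can be tied to a single structural change; they are simply the values as they stand.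

The next compound, compound 4, `COc1cc2c(cc1CC=C(C)C)/C(=N/O)C[C@@H](c1ccc(O)cc1)O2`, is not yet measured. It differs from compound 1 in one place: hydroxy in place of ureido on a double-bonded nitrogen. One hydrogen-bond donor and one acceptor remain at that nitrogen after the change, but the larger ureido group with its two donors is gone. Going by the values given here, nothing among the measured compounds shows this exact change, so the expectation rests on compound 1 alone, whose value in this assay is 87%.

The step expected in this assay is a number 15 percentage points lower from compound 1 to compound 4 (beyond the scatter), a modest move downward that may reach just beyond the scatter. Compound 4 is therefore estimated at 72%, within a range from 45% to 90%.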

Compound 4, percent growth inhibition at one concentration: 99%
Compound 4: the middle estimate sits 27 percentage points below what was measured; measured number outside the range, above it.
By their numbers in this assay, from the lowest: compounds 2 and 3 (each within the scatter of the next); then compound 1; then compound 4.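

Swapping ureido for hydroxy on a double-bonded nitrogen gives a number 12 percentage points higher from compound 1 to compound 4 (beyond the scatter) in this assay, and this is the first comparison here that isolates a single change. It shows that the larger ureido group is not required at this position for growth inhibition at the concentration tested, as the much smaller hydroxy, with one hydrogen-bond donor instead of two, does not lose inhibition and instead gains a modest amount. No measurement available here explains this gain, so the step stands as an observation without a known cause.

The result rests on one pair of compounds at one concentration, so it cannot say whether the gain would hold at lower concentrations or apply to other cores or other cell lines. It also leaves open how other small groups on the same nitrogen would compare, such as an amino group or an acetyl group, and whether any of them would match compound 4 at 99% in the same test.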